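The compounds below may be only part of what the source reports. "The series", "measured", "known", "first", "only" and "open" are said of these compounds alone.

Measured in a functional assay on NCI60 cells (Homo sapiens) for antiproliferative activity, read by sulforhodamine B assay, with a stated time of 48 h; on this read-out higher numbers stand for weaker inhibition of growth and lower numbers for stronger inhibition of growth:
- compound 1 `COc1ccc(-c2nsc3c2NC(=O)CC3c2cccc(OC)c2)cc1`: 1550 nM
- compound 2 `COc1ccc(-c2nsc3c2NC(=O)CC3c2cccc(Cl)c2)cc1`: 1740 nM
- compound 3 `COc1ccc(-c2nsc3c2NC(=O)CC3c2cccc(F)c2)cc1`: 4900 nM

Compound 3 has the highest number of the three, which means the weakest growth inhibition. Compound 4 `COc1ccc(-c2nsc3c2NC(=O)CC3c2ccc(F)cc2)cc1` has 4-fluorophenyl in place of 3-fluorophenyl on a saturated ring carbon. For the measured compounds named here, no measured step shows a fluorine changing place on its ring, so the guides are only indirect. Swapping one group for another gave modest steps (a 3.2-fold higher number from compound 1 to compound 3 (0.50 log units; beyond the scatter); a 2.8-fold higher number from compound 2 to compound 3 (0.45 log units; beyond the scatter)) or one within the scatter (a 1.1-fold higher number from compound 1 to compound 2 (0.05 log units; within the scatter)). A step of similar or smaller size is therefore plausible, and with compound 3 at 4900 nM at the top of the set, a lower number seems slightly likelier. The expected step in this assay is small (a 1.4-fold lower number from compound 3 to compound 4 (0.15 log units; within the scatter)). Compound 4 is estimated at 3500 nM (expected range 1400 nM to 9000 nM).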

Compound 4, concentration for 50% growth inhibition: 3020 nM
The estimate for compound 4 lay 1.2-fold (0.06 log units) above the measured number; the range from low to high includes it.
By their numbers in this assay, from the lowest: compounds 1, 2, 4 and 3 (each within the scatter of the next, the first and the last beyond it).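

Moving the fluorine, with 4-fluorophenyl in place of 3-fluorophenyl on the saturated ring carbon, gives a 1.6-fold lower number from compound 3 to compound 4 (0.21 log units; within the scatter), so this shift around the ring produces no change that stands clear of the scatter. Compound 4 also stays within the scatter of the other two compounds, with a 1.7-fold higher number from compound 2 to compound 4 (0.24 log units; within the scatter) and a 1.9-fold higher number from compound 1 to compound 4 (0.29 log units; within the scatter), whereas compound 3 lies beyond the scatter of both. Nothing available here explains these results.

Left open is how a phenyl ring carrying an amine or a carboxylic acid would read at this carbon. Also open, from the compounds shown here alone, is whether any ring is needed there at all.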